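Adding a Hydroxy Group to Compound 1

The compounds below may be only part of what the source reports. "The series", "measured", "known", "first", "only" and "open" are said of these compounds alone.

Compound 1 `Cc1cc(NC(=O)Nc2ccc(C(=O)O)cc2)c2ccccc2n1` was examined in an ADME assay on BJ cells (Homo sapiens) for cytotoxicity, with a stated time of 72 h; on this read-out higher numbers stand for an effect only at larger amounts of compound and lower numbers for an effect already at smaller amounts. In this assay compound 1 gives > 25000 nM, which is a limit of the assay rather than a number (the limit of > 25000 nM in this assay, at which 1 of the 2 values shown sits). Compound 2 `COC(=O)c1ccc(NC(=O)Nc2cc(C)nc3ccccc23)cc1`, with methyl in place of hydrogen on an oxygen next to a carbonyl group, gives 21000 nM in this assay; the step is an at least 1.1-fold lower number from compound 1 to compound 2 (0.07 log units; that floor lies within the scatter). Compound 3 `Cc1cc(NC(=O)Nc2ccc(C(=O)O)c(O)c2)c2ccccc2n1` differs from compound 1 by hydroxy in place of hydrogen on an aromatic carbon. Among the measured compounds shown here, the single measured step concerns another change and stayed within the scatter, so no step beyond the scatter is expected here. Compound 3 is therefore estimated at 30000 nM, with a range from 12000 nM to 80000 nM. The expected step is a step that the limit leaves unreadable from compound 1 to compound 3.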

Compound 3, half-maximal effective concentration: > 25000 nM
Compound 3 was reported as a limit (the forecaster's own chance of this, stated with the estimate: 60%); the middle value lies beyond the limit too.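

In this assay, among the compounds shown here, compound 1 and compound 3 both stand at a limit of the assay, so no step between them can be read: the limit of > 25000 nM in this assay, at which 2 of the 3 values shown sit. The compounds shown leave open whether hydroxy in place of hydrogen on an aromatic carbon changes this read-out at all.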